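The source may report more compounds than this note shows. Statements on the series, on what has been measured and on what is new or still open speak of the compounds shown alone.

Compound 1 `COc1ccc(F)cc1CNCCCNc1ccnc2cc(C3CCCCC3)ccc12` opens the set. In a physicochemical assay for solubility, with a stated time of 18 h, at pH 7.4 (on this read-out lower numbers stand for lower solubility and higher numbers for higher solubility), compound 1 gives 4200 nM. Compound 2 `COc1ccc(F)cc1CNCCCNc1ccnc2cc(Oc3ccc(C(C)(C)C)cc3)ccc12` carries 4-(tert-butyl)phenoxy in place of cyclohexyl on an aromatic carbon, and in this assay compound 2 gives 14500 nM, which amounts to a 3.5-fold higher number from compound 1 to compound 2 (0.54 log units; beyond the scatter). Among the compounds with values here, of the two numbers measured so far, compound 2 stands highest, and its only neighbour, compound 1, lies apart from it by a gap beyond the scatter.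

Compound 3 `COc1ccc(F)cc1CNCCCNc1ccnc2cc(-c3cccc4ccccc34)ccc12` is not yet measured. It differs from compound 2 in one place: naphthalen-1-yl in place of 4-(tert-butyl)phenoxy on an aromatic carbon. Within the data shown here, only one measured step exists, and it concerns a different exchange at the same aromatic carbon, so it bears on the coming step only as a gauge of how far a change at this position has moved the read-out, namely a 3.5-fold higher number from compound 1 to compound 2 (0.54 log units; beyond the scatter). Among the measured compounds shown here, no measured pair tells how this particular exchange behaves. A modest downward step of a 2.4-fold lower number from compound 2 to compound 3 (0.38 log units; beyond the scatter) is therefore expected, close to the edge of the scatter. For compound 3 the estimate in this assay is 6000 nM, with a range from 1500 nM to 20000 nM.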

Compound 3, solubility: 32000 nM
Estimate against measurement, compound 3: 5.3-fold (0.73 log units) below; the measured number lies above the stated range.
By their numbers in this assay, from the lowest: compound 1; then compound 2; then compound 3.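

In this assay, the exchange of 4-(tert-butyl)phenoxy for naphthalen-1-yl on this aromatic carbon gives a 2.2-fold higher number from compound 2 to compound 3 (0.34 log units; beyond the scatter), so compound 2 does not mark the top of the range seen at this position. Set against cyclohexyl, naphthalen-1-yl gives a 7.6-fold higher number from compound 1 to compound 3 (0.88 log units; beyond the scatter), the largest step among the three compounds, and all three steps lie beyond the scatter, so the groups at this one position now fall into a clear order: cyclohexyl lowest, 4-(tert-butyl)phenoxy in the middle and naphthalen-1-yl highest. Nothing available explains why the read-out moves in this direction, and the counted differences between the groups cannot settle that on their own.

All three groups shown at this position are built mainly from carbon, so it remains open how an amine, a carboxylic acid or a longer alkyl chain on the same aromatic carbon would read in this assay. Going by these compounds, it also remains open whether the order of these three groups would hold if another part of the shared core were changed.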